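Compound 3 in the cytotoxicity assay

The compounds below may be only part of what the source reports. "The series", "measured", "known", "first", "only" and "open" are said of these compounds alone.

Values in an ADME assay on BHK-21 cells (Mesocricetus auratus) for cytotoxicity, read by MTT assay; a lower number here means that less compound is tolerated, a higher number that more compound is tolerated:
Compound 1 `CC(=O)c1ccc2c(c1)nc(-c1ccccc1)n2C1CCCCC1`: 100000 nM
Compound 2 `C/C(=N\NC(N)=O)c1ccc2c(c1)nc(-c1ccccc1)n2C1CCCCC1`: > 100000 nM
Compound 3 `C/C(=N\NC(N)=S)c1ccc2c(c1)nc(-c1ccccc1)n2C1CCCCC1`: not yet measured

Compound 2 reads > 100000 nM in this assay, and this is a limit of the assay and not a number. The change to compound 3 lies on an amine nitrogen, and it is a group of 3 heavy atoms (1 carbon, 1 nitrogen, 1 sulfur; no ring) in place of a group of 3 heavy atoms (1 carbon, 1 nitrogen, 1 oxygen; no ring), on an amine nitrogen. The carbamoyl group leaves, and a group with sulfur where the carbamoyl group had oxygen enters.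

Within the data shown here, only one measured step comes close to this change: a number no lower from compound 1 to compound 2 (the limit leaves the size open). Its size cannot be read, and it concerns a different exchange on an aromatic carbon. Among the measured compounds shown here, no measured step shows oxygen giving way to sulfur, so the estimate has little to rest on. For the measured compounds named here, the only number in hand comes from compound 1, which gives 100000 nM. A modest downward move in this assay is therefore expected, and compound 3 may still return only a limit. The expected size of this move is an at least 1.4-fold lower number from compound 2 to compound 3 (0.15 log units; that floor lies within the scatter). For compound 3 the estimated value is 70000 nM, with an expected range of 20000 nM to 100000 nM.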

Compound 3, half-maximal cytotoxic concentration: 38000 nM
Compound 3: the middle estimate sits 1.8-fold (0.27 log units) above what was measured; measured number inside the range.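

Placing a group with sulfur where the carbamoyl group had oxygen, on an amine nitrogen, gives in this assay an at least 2.6-fold lower number from compound 2 to compound 3 (0.42 log units; beyond the scatter), so this single exchange moves the number beyond the scatter, something the earlier pair could not show. Compound 2 gives a limit of the assay and not a number, so the size of this step is only a floor: the limit of > 100000 nM in this assay, at which 1 of the 3 values shown sits. On the aromatic carbon, the larger group carrying sulfur in place of the smaller group gives a 2.6-fold lower number from compound 1 to compound 3 (0.42 log units; beyond the scatter), a step whose size can be read, whereas the matching step with the oxygen group cannot be read.

On these data alone, how far the number truly falls across the exchange of oxygen for sulfur stays open, and so does whether the same exchange would lower the number to a similar extent on another core. As far as these compounds go, how an amine or a carboxylic acid in place of the carbamoyl group, on the same amine nitrogen, would read in this assay also remains open.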